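The compounds below may be only part of what the source reports. "The series", "measured", "known", "first", "only" and "open" are said of these compounds alone.

Working notes on the quaternary ammonium series.

Compound 1 `C=CC[N+](C)(C)c1ccc(O)cc1` carries a hydroxyl on the aromatic ring. In a functional assay with Cavia porcellus as the target (on this read-out lower numbers stand for stronger inhibition and higher numbers for weaker inhibition), compound 1 gives only a limit, > 3000 nM. Compound 2 `C=CC[N+](C)(C)c1ccc(OC)cc1` carries the methyl ether instead, with the same chain on the nitrogen. In this assay compound 2 likewise gives only a limit, > 3000 nM. Compound 3 `COc1cccc([N+](C)(C)Cc2ccccc2)c1` bears a benzyl on the nitrogen. In this assay compound 3 also gives only a limit, > 3000 nM. The step from compound 1 to compound 2, a step that the two limits leave unreadable from compound 1 to compound 2, cannot be sized since every value shown sits at the limit (the limit of > 3000 nM in this assay, at which 3 of the 3 values shown sit). Compound 2 therefore stands at the limit and nowhere above it among the numbers in hand.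

Compound 4 `COc1ccc([N+](C)(C)Cc2ccccc2)cc1` differs from compound 2 by phenyl in place of vinyl on a saturated chain carbon bound to a nitrogen on an aromatic ring. Going by the values given here, no measured step covers this exchange; the only other benzyl compound, compound 3, is itself a limit. Compound 4 is expected to remain weak, estimated at 8000 nM with a range of 2500 nM to 40000 nM. The expected step is a step that the limit leaves unreadable from compound 2 to compound 4, most likely reported again as a limit.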

Compound 4, half-maximal inhibitory concentration: > 3000 nM
Compound 4 ended at the assay's limit; the forecaster's own chance of this, stated with the estimate: 80%; the middle value is on the limit's open side.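

Compound 2 and compound 4 both give only limits in this assay, so no step can be read between them: the limit of > 3000 nM in this assay, at which 4 of the 4 values shown sit.

The compounds shown leave open whether exchanging vinyl for phenyl changes inhibition at all, as none gives a readable number in this assay.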